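Acetamido in Place of Cyano and Cytotoxicity in Liver Cells

The compounds below may be only part of what the source reports. "The series", "measured", "known", "first", "only" and "open" are said of these compounds alone.

Compound 1 `N#Cc1ccc(S(=O)(=O)N2C/C(=C\c3ccccc3F)C(=O)/C(=C/c3ccccc3F)C2)cc1` and compound 2 `CC(=O)Nc1ccc(S(=O)(=O)N2C/C(=C\c3ccccc3F)C(=O)/C(=C/c3ccccc3F)C2)cc1` share one core, while compound 3 `N#Cc1ccc(S(=O)(=O)N2C/C(=C\c3ccc(F)cc3)C(=O)/C(=C/c3ccc(F)cc3)C2)cc1` and the still unmeasured compound 4 `CC(=O)Nc1ccc(S(=O)(=O)N2C/C(=C\c3ccc(F)cc3)C(=O)/C(=C/c3ccc(F)cc3)C2)cc1` share another; the difference between the two cores is not broken down here. In an ADME assay on L02 cells (Homo sapiens) for cytotoxicity, read by MTT assay, with a stated time of 24 h (on this read-out higher numbers stand for weaker inhibition and lower numbers for stronger inhibition), compound 1 gives 11000 nM, and compound 2 gives 11500 nM. The change between them is acetamido in place of cyano on an aromatic carbon, and it made a 1.0-fold higher number from compound 1 to compound 2 (0.02 log units; within the scatter). Compound 3 gives 14700 nM in this assay. Compound 4 carries the same change on the other core: acetamido in place of cyano on an aromatic carbon. Because a 1.0-fold higher number from compound 1 to compound 2 (0.02 log units; within the scatter), the corresponding step on the second core is expected to be small as well, namely a 1.0-fold higher number from compound 3 to compound 4 (0.01 log units; within the scatter). On that basis compound 4 is estimated to give 15000 nM in this assay, with a likely range from 8000 nM to 28000 nM.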

Compound 4, half-maximal inhibitory concentration: 19400 nM
Compound 4: middle estimate off by 1.3-fold (0.11 log units), on the low side; low and high end bracket the measured number.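

In this assay, acetamido in place of cyano made a 1.3-fold higher number from compound 3 to compound 4 (0.12 log units; within the scatter). Set beside the earlier step, the change carried from one core to the other without a difference that stands out from the scatter: the same change on two cores in this assay, a 1.0-fold higher number (0.02 log units; within the scatter) from compound 1 to compound 2 and a 1.3-fold higher number (0.12 log units; within the scatter) from compound 3 to compound 4, 1.3-fold (0.10 log units) apart, within the scatter of two such steps This shows that on these two cores, the swap left the number within the scatter, but with only two pairs of compounds it does not show that the step would stay this small on any other core.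

The compounds shown leave open what an amine, a carboxylic acid or a longer acyl chain on the nitrogen would do in place of the cyano. They also leave open whether such groups would carry across the two cores in the same way.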